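Swapping a saturated ring for a fluorinated aryl at a para position

The compounds below may be only part of what the source reports. "The series", "measured", "known", "first", "only" and "open" are said of these compounds alone.

Measured so far:
- compound 1 `Oc1ccccc1CNc1ccc(N2CCCCC2)cc1` — "not active" (no number reported)
- compound 2 `COc1ccc(-c2ccc(NCc3ccccc3O)cc2)cc1` — 580 nM
- compound 3 `Oc1ccccc1CNc1ccc(-c2cccc(OC(F)(F)F)c2)cc1` — "not active" (no number reported)

In a functional assay on Jurkat cells (Homo sapiens) for activation, with a stated time of 24 h (on this read-out lower numbers stand for an effect already at smaller amounts and higher numbers for an effect only at larger amounts of compound), compound 1 is reported as "not active" (no number reported), with no number attached. Compound 3 also has no number in this assay, so only compound 2 gives a value, and compound 1 cannot be placed on a scale against it. What the three compounds do show is that the shared core tolerates one six-membered aromatic ring of carbon only at this position, as in compound 2, while the saturated ring of compound 1 and the trifluoromethoxy-bearing ring of compound 3 gave no reportable effect.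

Compound 4 `Oc1ccccc1CNc1ccc(-c2ccccc2F)cc1` carries 2-fluorophenyl in place of piperidin-1-yl on an aromatic carbon. Within the data shown here, no step between compound 1 and compound 4 can be computed, since compound 1 has no number. The change brings compound 4 closer to compound 2 than to compound 1, so activity in this assay is expected to reappear, though with a real chance of another limit. Compound 4 is estimated at 1500 nM, within 300 nM to 8000 nM.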

Compound 4, half-maximal effective concentration: 2150 nM
Compound 4: the middle estimate sits 1.4-fold (0.16 log units) below what was measured; the range from low to high includes it.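

Among these compounds, compound 1 has no number in this assay, so no step from it to compound 4 can be read. The compounds shown leave open which feature of the 2-fluorophenyl group separates compound 4 from compound 3, which also has no number. No measurement here offers an explanation for these results.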